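A few compounds are considered here, and "the series" means these few. Any claim that something is new, unique, unknown or untested is made for them only; others in the source may bear on it.

Compound 1 `Cc1cc2c(cc1C(=O)N=C(N)N)S(=O)(=O)CC2(C)O` gives 30 nM in an assay on cells for inhibition of sodium/hydrogen exchanger (Oryctolagus cuniculus); on this read-out higher numbers stand for weaker inhibition and lower numbers for stronger inhibition. Compound 2 `COC1(C)CS(=O)(=O)c2cc(C(=O)N=C(N)N)c(C)cc21` differs from it only by methyl in place of hydrogen on an oxygen on a saturated carbon, and in this assay compound 2 gives 40 nM, so that the step is a 1.3-fold higher number from compound 1 to compound 2 (0.12 log units; within the scatter). Compound 3 `Cc1cc2c(cc1C(=O)N=C(N)N)S(=O)(=O)C(C)(C)C2O` is built on a different core; the difference between the two cores is not broken down here. In this assay compound 3 gives 28 nM, a number that lies within the usual scatter of both compound 1 and compound 2, so no order among the three can be read from these figures.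

Compound 4 `COC1c2cc(C)c(C(=O)N=C(N)N)cc2S(=O)(=O)C1(C)C` has not yet been measured. It differs from compound 3 by methyl in place of hydrogen on an oxygen on a saturated carbon, the same change that separates compound 1 from compound 2, now made on the core of compound 3. The expectation for compound 4 rests on that earlier pair alone, whose step was a 1.3-fold higher number from compound 1 to compound 2 (0.12 log units; within the scatter). In this assay the expected step is a 1.3-fold higher number from compound 3 to compound 4 (0.11 log units; within the scatter). Compound 4 is therefore estimated at 36 nM, most likely lying between 18 nM and 75 nM.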

Compound 4, half-maximal inhibitory concentration: 27 nM
The estimate for compound 4 lay 1.3-fold (0.12 log units) above the measured number; the range from low to high includes it.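

Replacing hydroxy by methoxy on the core of compound 3 gives, in this assay, a 1.0-fold lower number from compound 3 to compound 4 (0.02 log units; within the scatter). Set beside the earlier step, the change reads alike on both cores as far as these figures can tell: the same change on two cores in this assay, a 1.3-fold higher number (0.12 log units; within the scatter) from compound 1 to compound 2 and a 1.0-fold lower number (0.02 log units; within the scatter) from compound 3 to compound 4, 1.4-fold (0.14 log units) apart, within the scatter of two such steps. On these two cores, then, the change leaves the number within the scatter, and a step read on one core held for the other; this does not show that the change has no effect at all, as steps this small cannot be told apart from repeat scatter, and two cores say nothing about the rest of the series.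

The compounds shown carry only hydroxy and methoxy at this place, so it stays open whether a longer chain on that oxygen, such as ethyl, or an amine in place of the hydroxy, would move the number beyond the scatter. On these data alone, it also stays open whether the change would remain this small on a third core.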